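Sulfoximine variation on the aryl group of the series

The compounds below may be only part of what the source reports. "The series", "measured", "known", "first", "only" and "open" are said of these compounds alone.

Compound 2 `CC#C[C@H]1CN(S(=O)(=O)c2ccc(N)nc2)CCN1c1ccc(S(C)(=N)=O)cc1` stands at the weaker end of the two numbers in hand: in an assay on isolated protein for inhibition of glucokinase regulatory protein (Homo sapiens), read by AlphaScreen, with stated times of 20 min and 4 h (on this read-out higher numbers stand for weaker inhibition and lower numbers for stronger inhibition), compound 2 gives 310 nM. Going by the values given here, its only measured neighbour is compound 1 `CC#CCC(O)(c1ccc(N2CCN(S(=O)(=O)c3ccc(N)nc3)C[C@@H]2C#CC)cc1)C(F)(F)F`, which in this assay gives 5 nM, so that a 62-fold higher number from compound 1 to compound 2 (1.79 log units; beyond the scatter).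

Compound 3 `CC#C[C@H]1CN(S(=O)(=O)c2ccc(N)nc2)CCN1c1ccc(S(=O)(=NC)C(F)(F)F)cc1` is not yet measured. It differs from compound 2 at the same aromatic carbon, para to a large group: a group of 8 heavy atoms (2 carbon, 1 nitrogen, 1 oxygen, 3 fluorine, 1 sulfur; no ring) in place of a group of 4 heavy atoms (1 carbon, 1 nitrogen, 1 oxygen, 1 sulfur; no ring), on an aromatic carbon. Among the compounds with values here, the one measured step at this place is the one from compound 1 to compound 2, and it was large; it does not, however, cover the present change, since the group entering in compound 3 is neither the group of compound 1 nor that of compound 2. The entering group does carry, like the group of compound 1, a trifluoromethyl. No other comparison bears on the step.

With only this to go on, the expectation for compound 3 in this assay is a moderate step toward a lower number, a 3.1-fold lower number from compound 2 to compound 3 (0.49 log units; beyond the scatter). Compound 3 is therefore estimated at 100 nM, with a range from 25 nM to 400 nM.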

Compound 3, half-maximal inhibitory concentration: 266 nM
Compound 3: middle estimate off by 2.7-fold (0.42 log units), on the low side; the range from low to high includes it.
By their numbers in this assay, from the lowest: compound 1; then compounds 3 and 2 (each within the scatter of the next).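

At this aromatic carbon, para to a large group, the group of 8 heavy atoms in place of the group of 4 heavy atoms gives a 1.2-fold lower number from compound 2 to compound 3 (0.07 log units; within the scatter) in this assay, so the larger group and going from 1 hydrogen-bond donor to 0 produce no readable difference between these two compounds. The trifluoromethyl shared with the group of compound 1 does not bring compound 3 to the level of compound 1, since a 53-fold higher number from compound 1 to compound 3 (1.73 log units; beyond the scatter) is a large step, so a trifluoromethyl on the group is not enough by itself in these compounds. Nothing in hand explains either step.

Within the entering group, the trifluoromethyl and the methyl on nitrogen are read only together, so the share of each in the result stays open, as does which part of the group of compound 1, its hydroxyl or its butynyl chain, goes with the lower number in that compound. Going by these compounds, how a sulfone, a primary amine or a carboxylic acid on this aromatic carbon would read also remains open.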